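From 3-hydroxyphenyl to 2-formylphenyl: notes on compound 4

The source may report more compounds than this note shows. Statements on the series, on what has been measured and on what is new or still open speak of the compounds shown alone.

In a functional assay on HepG2 cells (Homo sapiens) for inhibition, read by MTT assay, with a stated time of 48 h (a lower number here means a stronger inhibitor, a higher number a weaker inhibitor), compound 1 `COc1ccc(/C=C/C(=O)c2cc(OC)c(OC)c(OC)c2)c(OC)c1` returns > 100000 nM as a limit of the assay and not a number. Compound 2 `COc1cccc(/C=C/C(=O)c2cc(OC)c(OC)c(OC)c2)c1O` gives 13500 nM in this assay and compound 3 `COc1cc(C(=O)/C=C/c2cccc(O)c2)cc(OC)c1OC` gives 94000 nM there. Compound 3 thus holds the higher of the two actual numbers, with a gap to compound 2 that lies beyond the scatter, and it is the weaker inhibitor of that pair.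

The next structure is compound 4 `COc1cc(C(=O)/C=C/c2ccccc2C=O)cc(OC)c1OC` which has 2-formylphenyl in place of 3-hydroxyphenyl on a double-bonded chain carbon bound to a double-bonded chain carbon with the rest of the structure unchanged. For the measured compounds named here, no measured pair isolates this change, so any expectation rests on the spread of the values alone. Compound 2 at 13500 nM shows that numbers well under that of compound 3 occur in this set. Compound 1 shows that a limit can also be the outcome. A small move toward a lower number is expected, an estimated 2.1-fold lower number from compound 3 to compound 4 (0.32 log units; beyond the scatter) in this assay with little confidence in its size. The estimate for compound 4 is 45000 nM in this assay with 12000 nM to 100000 nM as the expected range.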

Compound 4, half-maximal inhibitory concentration: > 100000 nM
Compound 4 was reported as a limit (the forecaster's own chance of this, stated with the estimate: 20%); middle value at least 2.2-fold (0.34 log units) away from the limit.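

Compound 4 reads > 100000 nM in this assay, and this is a limit of the assay and not a number. The exchange of 3-hydroxyphenyl for 2-formylphenyl on a double-bonded chain carbon bound to a double-bonded chain carbon brings no move toward a lower number, and the step reads an at least 1.0-fold higher number from compound 3 to compound 4 (0.02 log units; that floor lies within the scatter), so it gives only a floor and no order can be drawn between the two compounds. This is the first view of this place with the hydrogen-bond donor gone and a formyl group present, yet the read-out shows only that no gain appeared, with little room left to see a loss: the limit of > 100000 nM in this assay, at which 2 of the 4 values shown sit.

The compounds shown leave open whether the hydroxyl or the formyl group matters at all at this place, as a single exchange with a limit on one side cannot separate the loss of one group from the entry of the other. On these data alone, how a plain phenyl, or a ring carrying an amine or a carboxylic acid, would read in this assay also stays open, and only a value under the limit would give this step a size.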